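Replacing a ring amide on a shared core

The compounds below may be only part of what the source reports. "The series", "measured", "known", "first", "only" and "open" are said of these compounds alone.

Compound 1 `O=C(Nc1ccccc1)c1cnc(NCc2c(F)ccc3c2CCO3)n2cnnc12`: 14 mL.min-1.g-1
Compound 2 `CN(c1ncco1)c1cnc(NCc2c(F)ccc3c2CCO3)n2cnnc12`: 11 mL.min-1.g-1
Compound 3 `O=C1CCCN1c1cnc(NCc2c(F)ccc3c2CCO3)n2cnnc12`: < 3 mL.min-1.g-1

In an ADME assay on microsomes from liver (Homo sapiens) for metabolic stability, read by LC-MS, using NADPH, with stated times of 5 min and 30 min, tested at 1 uM (a higher number here means faster removal of the compound, a lower number slower removal), compound 3 gives only a limit, < 3 mL.min-1.g-1, and not a number.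

Compound 4 `CN(c1cccnc1)c1cnc(NCc2c(F)ccc3c2CCO3)n2cnnc12` has methyl(pyridin-3-yl)amino in place of 2-oxopyrrolidin-1-yl on an aromatic carbon.

Two measured steps end at compound 3, and both are beyond the scatter: an at least 4.6-fold lower number from compound 1 to compound 3 (0.66 log units; beyond the scatter) and an at least 3.6-fold lower number from compound 2 to compound 3 (0.56 log units; beyond the scatter). The second is the closer guide, since its starting group, methyl(1,3-oxazol-2-yl)amino, also carries a methyl group on the amino nitrogen. Read in reverse, it suggests that leaving 2-oxopyrrolidin-1-yl gives a higher number. The remaining step, a 1.3-fold lower number from compound 1 to compound 2 (0.10 log units; within the scatter), shows that the two groups other than 2-oxopyrrolidin-1-yl do not separate in this assay.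

The value of compound 4 is therefore expected to lie near that of compound 2, 11 mL.min-1.g-1. The expected change is a modest rise, an at least 3.6-fold higher number from compound 3 to compound 4 (0.56 log units; beyond the scatter). For compound 4 the estimated value is 11 mL.min-1.g-1, with an expected range of 5 mL.min-1.g-1 to 24 mL.min-1.g-1.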

Compound 4, intrinsic clearance in microsomes in the Homo sapiens assay: 80 mL.min-1.g-1
The estimate for compound 4 lay 7.3-fold (0.86 log units) below the measured number; measured number outside the range, above it.
By their numbers in the Homo sapiens assay, from the lowest: compounds 2 and 1 (each within the scatter of the next); then compound 4. At a limit, below all of these: compound 3.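

At this position the ring on the methyl-bearing amino nitrogen matters in the Homo sapiens assay: with pyridin-3-yl in place of 1,3-oxazol-2-yl there is a 7.3-fold higher number from compound 2 to compound 4 (0.86 log units; beyond the scatter), so a shared methylamino link does not fix the number. Methyl(pyridin-3-yl)amino also separates from phenylcarbamoyl, with a 5.7-fold higher number from compound 1 to compound 4 (0.76 log units; beyond the scatter), although compound 1 and compound 2 did not separate from each other. In the Homo sapiens assay compound 3 gives only a limit and not a number, so the size of an at least 26-fold higher number from compound 3 to compound 4 (1.42 log units; beyond the scatter) rests on that limit. In a physicochemical assay for solubility, read by LC-MS, in phosphate buffer, with a stated time of 24 h, at pH 7.4 (a higher number here means a more soluble compound, a lower number a less soluble compound), the same change also lowers the number, with compound 3 at 640000 nM and compound 4 at 47000 nM as measured: the measured solubility of compound 3, 640000 nM, and of compound 4, 47000 nM, a 14-fold lower number (1.13 log units; beyond the scatter)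

The compounds shown leave open whether a phenyl ring or a fluorinated pyridin-3-yl ring on the same nitrogen would give a number as high in the Homo sapiens assay. They also leave open what a secondary amine, without the methyl group, would give.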